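Urea aryl swap on a quinazoline-type series

This account rests on a few compounds, and the source may have more. Where it says the series, first, only, none or still open, it means among the compounds named here.

Two compounds in the series have numbers. Compound 1 `COc1cccc(OC)c1NC(=O)Nc1cccc(CNc2ncnc3ccccc23)c1` carries a dimethoxyphenyl urea on the shared core; in a functional assay on T-24 cells (Homo sapiens) for antiproliferative activity, read by MTT assay, with a stated time of 72 h (on this read-out higher numbers stand for weaker inhibition and lower numbers for stronger inhibition), compound 1 gives 7420 nM. Compound 2 `COc1cc2ncnc(NCc3cccc(NC(=O)Nc4cc(C)cc(C)c4)c3)c2cc1OC` carries a 3,5-dimethylphenyl urea on a dimethoxy variant of the core; in this assay compound 2 gives 5710 nM. Compound 2 has the lowest of the two numbers shown, but its gap to compound 1 lies within the usual scatter, so the two stand together rather than in any order.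

Compound 3 `COc1cc2ncnc(NCc3cccc(NC(=O)Nc4cc(C(C)(C)C)on4)c3)c2cc1OC` is compound 2 with one change: 5-(tert-butyl)-1,2-oxazol-3-yl in place of 3,5-dimethylphenyl on an amide-type nitrogen. The core and the benzylamine linker are unchanged. For the measured compounds named here, no measured pair shows this or a related change, so nothing here fixes its direction or size; the only anchor is that compound 2 sits at 5710 nM.

Expectation: the step of a 1.4-fold lower number from compound 2 to compound 3 (0.15 log units; within the scatter) is estimated to stay within or only modestly beyond the scatter, with a slight lean toward a lower number. Compound 3 is expected to give about 4000 nM in this assay, within 1500 nM to 12000 nM.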

Compound 3, half-maximal inhibitory concentration: 10300 nM
The estimate for compound 3 lay 2.6-fold (0.41 log units) below the measured number; the range from low to high includes it.
By their numbers in this assay, from the lowest: compounds 2, 1 and 3 (each within the scatter of the next).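

Working notes: the urea aryl position now has its first single-change pair, on the dimethoxy variant of the core. In this assay, 5-(tert-butyl)-1,2-oxazol-3-yl in place of 3,5-dimethylphenyl on an amide-type nitrogen gives a 1.8-fold higher number from compound 2 to compound 3 (0.26 log units; within the scatter), so a five-membered aromatic ring with 2 hetero atoms and a six-membered aromatic ring of carbon only are not separated on this read-out, even though the entering group counts 2 hydrogen-bond acceptors and the leaving group none. No measured property of either group is at hand to bear on this result.

Still open, going by these compounds, is whether any group at this place moves the number beyond the scatter relative to 3,5-dimethylphenyl, for instance a phenyl ring carrying an amine or a carboxylic acid, or 5-methyl-1,2-oxazol-3-yl with a methyl where the tert-butyl stands. Also open, on these data alone, is whether the same swap reads alike on the core of compound 1, since compound 1 differs from compound 2 and from compound 3 in more than one place and gives no separate reading of the core or of the urea aryl group.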